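Replacing the acid chain in a leukotriene receptor series

The compounds below may be only part of what the source reports. "The series", "measured", "known", "first", "only" and "open" are said of these compounds alone.

Compound 1 `CC(=O)c1cc(C=O)c(OCCCCC#N)cc1O`: 6%
Compound 2 `C=CCc1cc(C(C)=O)c(O)cc1OCCCCCC#N`: 81%
Compound 3 `CCc1cc(C(C)=O)c(O)cc1OCCCC(C)(C)C(=O)O`: 89%

In an assay on isolated protein for inhibition of leukotriene B4 receptor 1 (Homo sapiens), tested at 10 uM (on this read-out higher numbers stand for more inhibition at the one concentration tested (going by the name of the read-out) and lower numbers for less inhibition), compound 3 gives the highest of the three numbers. Its nearest neighbour is compound 2, whose number is lower by an amount within the scatter, so the two cannot be ordered; compound 1 lies far below, beyond the scatter.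

Compound 4 `CCc1cc(C(C)=O)c(O)cc1OCCCCCC[S+](C)[O-]` differs from compound 3 in one place: a group of 6 heavy atoms (4 carbon, 1 oxygen, 1 sulfur; no ring) in place of a group of 6 heavy atoms (4 carbon, 2 oxygen; no ring), on a saturated chain carbon, three bonds along the chain from an oxygen on an aromatic ring. Among the measured compounds shown here, no measured pair shows this change directly. A small loss is expected, because compound 2 carries no carboxylic acid and still gives 81% in this assay. The step of a number 19 percentage points lower from compound 3 to compound 4 (beyond the scatter) is therefore expected to be modest, perhaps no larger than the scatter. For compound 4 the expected value is 70%, within a range from 40% to 92%.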

Compound 4, a percentage reported as inhibition, at one concentration (the size of the read-out at that concentration, not a potency): 92%
Compound 4: middle estimate off by 22 percentage points, on the low side; measured number inside the range.
By their numbers in this assay, from the lowest: compound 1; then compounds 2, 3 and 4 (each within the scatter of the next, the first and the last beyond it).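

In this assay, the 1-carboxy-1-methylethyl group gives way to a sulfur-bearing group with no ring, on a saturated chain carbon, with a number 3 percentage points higher from compound 3 to compound 4 (within the scatter), so at this place the carboxylic acid can be absent without a loss beyond the scatter. Among the compounds shown here, compound 2 also lacks the acid, but it differs from compound 3 in more than one place, so only this pair isolates the change. Nothing measured here explains why the two groups read alike. The compounds shown leave open whether an amine or a primary amide at this place would give a similar number, and what a shorter chain would do.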